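Fluoro to chloro in a cytotoxic sulfonyl series

The source may report more compounds than this note shows. Statements on the series, on what has been measured and on what is new or still open speak of the compounds shown alone.

Measured so far:
- compound 1 `Cc1ccc(S(=O)(=O)N2C/C(=C\c3cccnc3)C(=O)/C(=C/c3ccccc3C(F)(F)F)C2)cc1`: 6170 nM
- compound 2 `O=C1/C(=C/c2cccnc2)CN(S(=O)(=O)c2ccc(F)cc2)C/C1=C\c1ccccc1C(F)(F)F`: 6030 nM

Among the measured compounds shown here, in a functional assay on QGY-7703 cells (Homo sapiens) for cytotoxicity, read by MTT assay, with a stated time of 24 h (a lower number here means a stronger inhibitor, a higher number a weaker inhibitor), compound 2 gives 6030 nM, which stands level with compound 1, the only other compound measured, as the two values lie within the scatter of each other. The next compound, compound 3 `O=C1/C(=C/c2cccnc2)CN(S(=O)(=O)c2ccc(Cl)cc2)C/C1=C\c1ccccc1C(F)(F)F`, keeps the shared core and differs from compound 2 in one substituent (chloro in place of fluoro on an aromatic carbon). It carries chloro in place of fluoro on an aromatic carbon, para to a large group, so that 4-fluorophenyl becomes 4-chlorophenyl.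

For the measured compounds named here, only one measured step bears on this place. That step, a 1.0-fold lower number from compound 1 to compound 2 (0.01 log units; within the scatter), put fluoro in place of methyl on the same aromatic carbon. Going by the values given here, it is a single step, and no chloro compound has yet been measured, so the basis is thin. Even so, nothing in it suggests a shift beyond the scatter for this swap. The estimated step is a 1.0-fold lower number from compound 2 to compound 3 (0.02 log units; within the scatter), which is expected to stay within the scatter.

In this assay the estimate for compound 3 is 5800 nM, with the measurement expected to fall from 3200 nM to 10500 nM.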

Compound 3, half-maximal inhibitory concentration: 3440 nM
For compound 3 the middle estimate is 1.7-fold (0.23 log units) above the measured one, within the range that was stated.
By their numbers in this assay, from the lowest: compounds 3, 2 and 1 (each within the scatter of the next).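

Compound 3 brings a second halogen to this aromatic carbon, so the position has now carried methyl, fluoro and chloro, where the earlier pair offered only methyl and fluoro. In this assay, replacing 4-fluorophenyl with 4-chlorophenyl gives a 1.8-fold lower number from compound 2 to compound 3 (0.24 log units; within the scatter), and replacing methyl with chloro on the same carbon gives a 1.8-fold lower number from compound 1 to compound 3 (0.25 log units; within the scatter), so neither change leaves the scatter and all three compounds stand level. Nothing measured here explains why these three groups read alike in this cell assay.

The compounds shown leave open whether a group of another kind on this carbon, such as an amine, a carboxylic acid or a longer alkyl chain, would shift the number beyond the scatter, since methyl, fluoro and chloro are the only groups seen at this position. They also leave open whether this level reading would hold if the trifluoromethyl group on the other aromatic ring gave way to a nitrile, since all three compounds carry trifluoromethyl there.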